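A few compounds are considered here, and "the series" means these few. Any claim that something is new, unique, unknown or untested is made for them only; others in the source may bear on it.

Compound 1 `CN(C)C(=O)Cn1cc(C(=O)Nc2ccc(-c3cn(C)c4ncnc(N)c34)cc2)c(=O)c(-c2ccc(F)cc2)c1`: 0.5 nM
Compound 2 `Cn1cc(-c2ccc(NC(=O)c3cn(C4CCOCC4)cc(-c4ccc(F)cc4)c3=O)cc2)c2c(N)ncnc21`: 1.1 nM

Among the measured compounds shown here, in an assay on isolated protein for inhibition of tyrosine-protein kinase receptor UFO (Homo sapiens), read by ELISA (on this read-out higher numbers stand for weaker inhibition and lower numbers for stronger inhibition), compound 2 gives 1.1 nM, the higher of the two numbers measured so far. Its nearest neighbour, compound 1, gives 0.5 nM. For the measured compounds named here, the single measured step, a 2.2-fold higher number from compound 1 to compound 2 (0.34 log units; beyond the scatter), shows that the group on this aromatic nitrogen shifts the read-out modestly. Compound 3 `Cn1cc(C(=O)Nc2ccc(-c3cn(C)c4ncnc(N)c34)cc2)c(=O)c(-c2ccc(F)cc2)c1` carries methyl in place of oxan-4-yl on an aromatic nitrogen. Going by the values given here, only that one step bears on the change, and it points to a shift of modest size at most in this assay, with no direction fixed. Compound 3 is therefore expected near 0.8 nM, within 0.3 nM to 2.5 nM, a step of a 1.4-fold lower number from compound 2 to compound 3 (0.14 log units; within the scatter) that may well lie within the scatter.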

Compound 3, half-maximal inhibitory concentration: 5 nM
Compound 3: middle estimate off by 6.3-fold (0.80 log units), on the low side, and the stated range ends below it.
By their numbers in this assay, from the lowest: compound 1; then compound 2; then compound 3.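

Methyl on this aromatic nitrogen proves clearly worse than either of the other groups in this assay: replacing oxan-4-yl gives a 4.5-fold higher number from compound 2 to compound 3 (0.66 log units; beyond the scatter), and replacing (dimethylcarbamoyl)methyl gives a 10-fold higher number from compound 1 to compound 3 (1.00 log units; beyond the scatter). Inhibition at this position therefore does not persist with methyl alone, and both oxan-4-yl and (dimethylcarbamoyl)methyl hold the number lower. No evidence is available to explain this difference.

Going by these compounds, it remains open which feature of those two groups matters, and whether an amine or a carboxylic acid at the end of a longer chain on this nitrogen would keep the lower numbers.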